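A few compounds are considered here, and "the series" means these few. Any claim that something is new, unique, unknown or untested is made for them only; others in the source may bear on it.

Measured set, in a functional assay on A549 cells (Homo sapiens) for antiproliferative activity, read by XTT assay, with a stated time of 72 h; on this read-out lower numbers stand for stronger inhibition and higher numbers for weaker inhibition:
- compound 1 `COc1ccc(-c2cc3ccccc3nc2/C=C/C(=O)c2ccc(OC)cc2OC)cc1`: 7990 nM
- compound 2 `COc1ccc(-c2cc3ccccc3nc2/C=C/C(=O)c2ccc(OC)c(OC)c2)cc1`: 8860 nM
- compound 3 `COc1ccc(-c2cc3ccccc3nc2/C=C/C(=O)c2ccco2)cc1`: 6130 nM

All three compounds share the same core and differ only in the group on the carbonyl carbon. Compound 1 gives the second highest of the three numbers in this assay; its nearest neighbour is compound 2 a 1.1-fold higher number from compound 1 to compound 2 (0.04 log units; within the scatter) and its furthest is compound 3 a 1.3-fold lower number from compound 1 to compound 3 (0.12 log units; within the scatter). The third pair is no wider a 1.4-fold lower number from compound 2 to compound 3 (0.16 log units; within the scatter). Nothing in this set separates the three groups beyond the scatter.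

Compound 4 `COc1ccc(-c2cc3ccccc3nc2/C=C/C(=O)c2ccsc2)cc1` is the next member, not yet measured. Against compound 1 the change is thiophen-3-yl in place of 2,4-dimethoxyphenyl on a carbonyl carbon.

The step most like this one is the move from compound 1 to compound 3, where a five-membered aromatic ring with one hetero atom also replaced the 2,4-dimethoxyphenyl, and that step stayed within the scatter a 1.3-fold lower number from compound 1 to compound 3 (0.12 log units; within the scatter). The move from compound 2 to compound 3 tells the same a 1.4-fold lower number from compound 2 to compound 3 (0.16 log units; within the scatter). On this basis the expected step in this assay from compound 1 to compound 4 is small, if anything toward a lower number, and not beyond the scatter: a 1.2-fold lower number from compound 1 to compound 4 (0.09 log units; within the scatter). For compound 4 the estimate in this assay is 6500 nM, with a range from 3000 nM to 14000 nM.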

Compound 4, half-maximal inhibitory concentration: 8210 nM
Compound 4: the middle estimate sits 1.3-fold (0.10 log units) below what was measured; measured number inside the range.
By their numbers in this assay, from the lowest: compounds 3, 1, 4 and 2 (each within the scatter of the next).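

Thiophen-3-yl on the carbonyl carbon, a group of 5 heavy atoms with sulfur as its hetero atom, extends the flat picture in this assay to a third ring type: it cannot be told apart from the 2,4-dimethoxyphenyl group (a 1.0-fold higher number from compound 1 to compound 4 (0.01 log units; within the scatter)) or from the 3,4-dimethoxyphenyl group (a 1.1-fold lower number from compound 2 to compound 4 (0.03 log units; within the scatter)). Swapping furan-2-yl for thiophen-3-yl also leaves the reading within the scatter (a 1.3-fold higher number from compound 3 to compound 4 (0.13 log units; within the scatter)), so among these four compounds neither the hetero atom of the five-membered ring nor the drop from 10 heavy atoms to 5 separates one group from another, and no compound shown goes against this. Nothing on hand explains why these groups read alike.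

All four groups shown are aromatic rings, so it remains open whether a cyclohexyl group or a straight alkyl chain on the carbonyl carbon would move the number beyond the scatter. Equally open, as far as these compounds go, is whether a phenyl ring carrying a dimethylamino group or a carboxylic acid would break the flat picture in this assay.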